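From Methyl to Thiophen-2-yl on a Saturated Chain

The source may hold more compounds than are shown below. What is called first, only, known or untested is meant among the compounds shown, and "the series" means these compounds.

In an ADME assay on Vero cells (Chlorocebus sabaeus) for cytotoxicity, read by MTT assay, with a stated time of 72 h (on this read-out higher numbers stand for weaker inhibition and lower numbers for stronger inhibition), compound 1 (`CC[S+]([O-])CCCCN=C=S`) gives 7900 nM and compound 3 (`[O-][S+](CCCCN=C=S)Cc1ccccn1`) gives 7650 nM as two readings that repeated measurements could not tell apart. Compound 2 (`O=[N+]([O-])c1ccc(C[S+]([O-])CCCCN=C=S)cc1`) gives 3360 nM as a number clearly lower than that of compound 1 and beyond the usual scatter. Compound 1 therefore stands at the upper end of this small set, level with compound 3.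

Compound 4 (`[O-][S+](CCCCN=C=S)Cc1cccs1`) has not been measured yet. Going from compound 1 to compound 4 puts thiophen-2-yl in place of methyl on a saturated chain carbon bound to a sulfur. Going by the values given here, no measured pair isolates a single change, so the evidence here is indirect. Compound 2 and compound 3 also carry an aromatic ring. Compound 3 reads 7650 nM while compound 2 reads 3360 nM and compound 4 is expected to land within that span. The estimated step is a 1.4-fold lower number from compound 1 to compound 4 (0.16 log units; within the scatter) and it is expected to point toward a lower number while staying within the usual scatter. Compound 4 is estimated at 5500 nM in this assay with an expected range from 2800 nM to 10000 nM once it is measured.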

Compound 4, half-maximal inhibitory concentration: 6220 nM
Compound 4: middle estimate off by 1.1-fold (0.05 log units), on the low side; the measured number falls inside the stated range.
By their numbers in this assay, from the lowest: compounds 2, 4, 3 and 1 (each within the scatter of the next, the first and the last beyond it).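

Putting thiophen-2-yl in place of methyl on a saturated chain carbon bound to a sulfur gives, in this assay, a 1.3-fold lower number from compound 1 to compound 4 (0.10 log units; within the scatter) and so leaves the two compounds indistinguishable on this read-out. This is the first pair shown that differs in only one place, so the change can now be read directly rather than inferred from compounds that differ from each other in other ways. It shows that this position can carry a five-membered aromatic ring with one hetero atom, rather than a single carbon, with no change in the number beyond the usual scatter. No measurement shown here explains this result.

Still open, going by these compounds, is whether an amine or a carboxylic acid in this place, or a longer chain in place of the methyl, would give a number beyond the scatter. On these data alone, it also remains unknown whether thiophen-2-yl would give the same outcome on a different core.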